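This account rests on a few compounds, and the source may have more. Where it says the series, first, only, none or still open, it means among the compounds named here.

Compound 3 (`Cn1cc(-c2cnc3ccnc(NC(=O)c4cccnc4)c3c2)cn1`) stands at > 50000 nM in a functional assay on A549 cells (Homo sapiens) for antiproliferative activity, read by MTT assay, with a stated time of 48 h (a lower number here means a stronger inhibitor, a higher number a weaker inhibitor), which is a limit of the assay and not a number. Compound 1 (`CC(=O)Nc1nccc2ncc(-c3cnn(C)c3)cc12`) gives > 50000 nM, also a limit. Compound 2 (`Cn1cc(-c2cnc3ccnc(NC(=O)C4CC4)c3c2)cn1`) gives > 50000 nM, again a limit. For the measured compounds named here, the series so far comes down to the limit of > 50000 nM in this assay, at which 3 of the 3 values shown sit.

Compound 4 (`CCNc1nccc2ncc(-c3cnn(C)c3)cc12`) is the next to be read, with ethyl in place of (pyridin-3-yl)carbonyl on a nitrogen on an aromatic ring. The measured steps all concern the group on the carbonyl carbon: a step that the two limits leave unreadable from compound 1 to compound 2, a step that the two limits leave unreadable from compound 1 to compound 3 and a step that the two limits leave unreadable from compound 2 to compound 3. None of them gives a size, and none removes the carbonyl, so they offer no size to carry over to this change. Going by the values given here, the only guide is that all three amides sit at the same limit, so no clear gain is expected in this assay. The expected move is an at least 1.1-fold lower number from compound 3 to compound 4 (0.04 log units; that floor lies within the scatter), an estimate that stays close to that limit. For compound 4 the estimated value is 45000 nM, with an expected range of 15000 nM to 100000 nM.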

Compound 4, half-maximal inhibitory concentration: 40700 nM
The estimate for compound 4 lay 1.1-fold (0.04 log units) above the measured number, within the range that was stated.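

In this assay compound 4 gives 40700 nM, the only number in the series so far that is not a limit, and it is the first compound shown with ethyl rather than a carbonyl group on this nitrogen on an aromatic ring. The steps read as an at least 1.2-fold lower number from compound 3 to compound 4 (0.08 log units; that floor lies within the scatter) and an at least 1.2-fold lower number from compound 2 to compound 4 (0.08 log units; that floor lies within the scatter) and an at least 1.2-fold lower number from compound 1 to compound 4 (0.08 log units; that floor lies within the scatter) and, with each floor within the scatter, they do not yet show that losing the carbonyl changes the number. The three amides, compounds 1, 2 and 3, remain at a limit of the assay: the limit of > 50000 nM in this assay, at which 3 of the 4 values shown sit.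

Going by these compounds, the true size of these steps stays open while the amides give only a limit. Also open, on these data alone, is how a propyl chain, a longer alkyl chain or an unsubstituted amine would read on this nitrogen.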